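The source may hold more compounds than are shown below. What is called first, only, known or untested is meant among the compounds shown, and "the series" means these compounds.

Measured compounds:
Compound 1, `COc1ccc(Cn2c(CCc3ccccc3)nnc2[C@H](NC(=O)c2ccccn2)c2c[nH]c3ccccc23)cc1`, gives 12 nM in a functional assay on CHO cells for antagonist activity at growth hormone secretagogue receptor type 1 (Homo sapiens); on this read-out lower numbers stand for stronger inhibition and higher numbers for weaker inhibition.
Compound 2, `COc1ccc(Cn2c(CCc3ccccc3)nnc2[C@H](NC(=O)Cc2ccccn2)c2c[nH]c3ccccc23)cc1`, gives 6 nM in this assay.
Compound 3, `COc1ccc(Cn2c(CCc3ccccc3)nnc2[C@H](NC(=O)CCc2cccnc2)c2c[nH]c3ccccc23)cc1`, gives "not determined" (no result reported) in this assay, that is, no result.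

Compound 3 therefore stands nowhere on the numbers shown: its value in this assay was not determined, so its position relative to compound 1 and compound 2 cannot be stated.

Compound 4, `COc1ccc(Cn2c(CCc3ccccc3)nnc2[C@H](NC(=O)c2cnccn2)c2c[nH]c3ccccc23)cc1`, differs from compound 3 in one place: pyrazin-2-yl in place of 2-(pyridin-3-yl)ethyl on a carbonyl carbon. Going by the values given here, the one measured step that bears on this change is the exchange of a ring bound to the carbonyl carbon for a ring held one carbon further away, which gave a 2.0-fold lower number from compound 1 to compound 2 (0.30 log units; within the scatter). That step lay within the scatter, so the data give no sign that moving a six-membered aromatic ring closer to, or further from, the carbonyl carbon shifts the number beyond the scatter. Compound 4 carries its ring on the carbonyl carbon as compound 1 does, and compound 1 gives 12 nM. Compound 4 is expected to fall in the same region as compound 1 and compound 2, with no step beyond the scatter in either direction, at an estimated 10 nM, within a range of 3 nM to 40 nM.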

Compound 4, antagonist equilibrium constant: 530 nM
The estimate for compound 4 lay 53-fold (1.72 log units) below the measured number; measured number above the stated range.
By their numbers in this assay, from the lowest: compounds 2 and 1 (each within the scatter of the next); then compound 4.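

Going by these compounds alone, compound 4 shows that this position on the carbonyl carbon is far less forgiving than the earlier compounds suggested: in this assay, keeping a six-membered aromatic ring directly on the carbonyl carbon but exchanging pyridin-2-yl for pyrazin-2-yl gives a 44-fold higher number from compound 1 to compound 4 (1.65 log units; beyond the scatter). The exchange of (pyridin-2-yl)methyl for pyrazin-2-yl gives a step of similar size, an 88-fold higher number from compound 2 to compound 4 (1.95 log units; beyond the scatter), whereas the earlier change in ring distance alone stayed within the scatter, so the identity of the ring here matters in a way compound 1 and compound 2 could not reveal. Nothing available explains why the number rises so steeply with pyrazin-2-yl.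

With no result for compound 3, the step from its 2-(pyridin-3-yl)ethyl group to pyrazin-2-yl cannot be read. From the compounds shown here alone, it also remains open whether (pyrazin-2-yl)methyl would restore the number seen with (pyridin-2-yl)methyl, and whether pyrimidin-2-yl or a plain phenyl on the carbonyl carbon would behave like pyridin-2-yl or like pyrazin-2-yl.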